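Chloro to fluoro on the pendant phenyl across two cores

This account rests on a few compounds, and the source may have more. Where it says the series, first, only, none or still open, it means among the compounds named here.

Measured so far:
compound 1 `Cn1ncc2c(NC(=O)NCc3cc(C(F)(F)F)nn3-c3cccc(Cl)c3)cccc21`: 2.3 nM
compound 2 `CC(C)(C)c1cc(CNC(=O)Nc2cccc3[nH]ncc23)n(-c2cccc(Cl)c2)n1`: 0.6 nM
compound 3 `Cn1ncc2c(NC(=O)NCc3cc(C(F)(F)F)nn3-c3cccc(F)c3)cccc21`: 7 nM

All three were run in an assay on CHO-K1 cells for antagonist activity at transient receptor potential cation channel subfamily V member 1 (Homo sapiens), read by FLIPR and calcium flux, with a stated time of 6 min; on this read-out higher numbers stand for weaker inhibition and lower numbers for stronger inhibition. Compound 2 gives the lowest number of the three, and its steps to compound 1 and compound 3 both lie beyond the scatter. The difference between the core of compound 1 and the core of compound 2 is not broken down here. Compound 3 differs from compound 1 only by fluoro in place of chloro on an aromatic carbon; the measured step is a 3.0-fold higher number from compound 1 to compound 3 (0.48 log units; beyond the scatter). Compound 4 `CC(C)(C)c1cc(CNC(=O)Nc2cccc3[nH]ncc23)n(-c2cccc(F)c2)n1`, not yet measured, stands to compound 2 as compound 3 stands to compound 1: the change is fluoro in place of chloro on an aromatic carbon, the same change at the same place on a different core. Among the measured compounds shown here, for compound 4 in this assay the expected step is a 3.0-fold higher number from compound 2 to compound 4 (0.48 log units; beyond the scatter), resting on the one measured instance a 3.0-fold higher number from compound 1 to compound 3 (0.48 log units; beyond the scatter). Because a 3.0-fold higher number from compound 1 to compound 3 (0.48 log units; beyond the scatter) was measured on another core, the expected range is kept wide. Compound 4 is estimated at 1.8 nM, between 0.8 nM and 4.5 nM.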

Compound 4, inhibition constant: 1.3 nM
Compound 4: middle estimate off by 1.4-fold (0.14 log units), on the high side; low and high end bracket the measured number.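

In this assay, fluoro in place of chloro on an aromatic carbon gives a 2.2-fold higher number from compound 2 to compound 4 (0.34 log units; beyond the scatter). Set beside the earlier step, the change carries over to the second core with a size that cannot be told apart: the same change on two cores in this assay, a 3.0-fold higher number (0.48 log units; beyond the scatter) from compound 1 to compound 3 and a 2.2-fold higher number (0.34 log units; beyond the scatter) from compound 2 to compound 4, 1.4-fold (0.15 log units) apart, within the scatter of two such steps. These are two cores and one replacement, which shows that the step held on these two cores but not that it would hold on any further core, and the numbers give no reason for the step.

Still open, going by these compounds, is whether a methoxy group, a nitrile or plain hydrogen in this place, meta to a large group, would behave alike on both cores. Also open, on these data alone, is whether the 3-chlorophenyl to 3-fluorophenyl step holds in any other assay.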